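Moving carbons from the chain onto the amine

A few compounds are considered here, and "the series" means these few. Any claim that something is new, unique, unknown or untested is made for them only; others in the source may bear on it.

Measured so far in a functional assay on LNCaP cells (Homo sapiens) for antiproliferative activity, read by WST assay, with a stated time of 3 days (a lower number here means a stronger inhibitor, a higher number a weaker inhibitor), as an antiproliferative read-out:
- compound 1 `CCCC(C)Oc1c(-c2cc(OC)c(OC)c(OC)c2)oc2ccccc2c1=O` gives 15100 nM
- compound 2 `CCCN(CCC)CCCOc1c(-c2cc(OC)c(OC)c(OC)c2)oc2ccccc2c1=O` gives 17900 nM
- compound 3 `CCCN(CCC)CCCCCOc1c(-c2cc(OC)c(OC)c(OC)c2)oc2ccccc2c1=O` gives 7600 nM

Compound 3 stands at the low end of this small set. The gap to its nearer neighbour is a 2.0-fold lower number from compound 1 to compound 3 (0.30 log units; within the scatter) and the gap to the other is a 2.4-fold lower number from compound 2 to compound 3 (0.37 log units; beyond the scatter) as the only clear move.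

Compound 4 `CCCCN(CCCC)CCCOc1c(-c2cc(OC)c(OC)c(OC)c2)oc2ccccc2c1=O` is not yet measured. It holds the same atoms as compound 3, joined differently: dibutylamino in place of 2-(dipropylamino)ethyl on a saturated chain carbon, three bonds along the chain from an oxygen on an aromatic ring and, cut one bond further out, this reads 5-(dipropylamino)pentyl to 3-(dibutylamino)propyl.

The most useful guide is compound 2, which also has a 3-substituted propyl chain and shows a 2.4-fold lower number from compound 2 to compound 3 (0.37 log units; beyond the scatter) in the comparison with the pentyl chain. Among the measured compounds shown here, no measured step shows dibutylamino replacing dipropylamino, so that part of the change remains open.

A small move to a higher number in this assay is therefore expected, a 1.5-fold higher number from compound 3 to compound 4 (0.18 log units; within the scatter) as the estimated step. Compound 4 is estimated at 11500 nM with an expected range from 5000 nM to 24000 nM in this test.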

Compound 4, half-maximal inhibitory concentration: 9000 nM
Compound 4: middle estimate off by 1.3-fold (0.11 log units), on the high side; the measured number falls inside the stated range.
By their numbers in this assay, from the lowest: compounds 3, 4, 1 and 2 (each within the scatter of the next, the first and the last beyond it).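

In this assay, shifting carbons from the chain onto the amine while keeping the same atoms gives a 1.2-fold higher number from compound 3 to compound 4 (0.07 log units; within the scatter) and so does not separate the two compounds. Dibutylamino in place of dipropylamino, a swap not seen in the earlier compounds, gives a 2.0-fold lower number from compound 2 to compound 4 (0.30 log units; within the scatter) on the same propyl chain, while the comparison with the amine-free side chain gives a 1.7-fold lower number from compound 1 to compound 4 (0.22 log units; within the scatter) as a further step that cannot be told from noise. Compound 4 thus lies within the scatter of all three others even though compound 2 and compound 3 lie beyond it of each other, and no other data here bear on this result.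

Still open, on these data alone, is how a 5-(dibutylamino)pentyl chain would compare with compound 3 and compound 4. A ring amine such as piperidine or morpholine at the end of the propyl chain is also untested in the compounds shown.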